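The source may hold more compounds than are shown below. What is called first, only, known or untested is meant among the compounds shown, and "the series" means these compounds.

Measured in a functional assay on A549 cells (Homo sapiens) for antiproliferative activity, read by XTT assay, with a stated time of 24 h; on this read-out higher numbers stand for weaker inhibition and lower numbers for stronger inhibition:
- compound 1 `Fc1ccc(C2CC(c3ccc(Cl)s3)=NN2c2nc(-c3ccc(Cl)cc3)cs2)cc1`: 125 ug/mL
- compound 2 `Cc1ccc(-c2csc(N3N=C(c4ccc(C)s4)CC3c3ccc(F)cc3)n2)cc1`: > 500 ug/mL (a limit)
- compound 3 `Fc1ccc(C2CC(c3ccc(Cl)s3)=NN2c2nc(-c3ccc(C(F)(F)F)cc3)cs2)cc1`: > 500 ug/mL (a limit)

The result for compound 2 is a limit of the assay, not a number. It sits at the limit of > 500 ug/mL in this assay, at which 2 of the 3 values shown sit, so the step that follows has no exact starting point.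

Compound 4 `Cc1ccc(C2=NN(c3nc(-c4ccc([N+](=O)[O-])cc4)cs3)C(c3ccc(F)cc3)C2)s1` differs from compound 2 in one group: nitro in place of methyl on an aromatic carbon. In other words, 4-methylphenyl becomes 4-nitrophenyl. One measured step involves a similar swap on an aromatic carbon: an at least 4.0-fold higher number from compound 1 to compound 3 (0.60 log units; beyond the scatter), which lies beyond the scatter. Going by the values given here, that step involves neither methyl nor nitro, so it shows only that a single group change can matter, not which way this one will go.

Only compound 1, at 125 ug/mL, gives a true number in this assay, so a modest move towards a lower number is expected, held loosely. The expected step is an at least 1.4-fold lower number from compound 2 to compound 4 (0.15 log units; that floor lies within the scatter). For compound 4 the estimated value is 350 ug/mL, with an expected range from 100 ug/mL to 1000 ug/mL.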

Compound 4, half-maximal inhibitory concentration: 16.7 ug/mL
The estimate for compound 4 lay 21-fold (1.32 log units) above the measured number; measured number below the stated range.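

Changing 4-methylphenyl to 4-nitrophenyl in this assay gives an at least 29-fold lower number from compound 2 to compound 4 (1.47 log units; beyond the scatter) and is the first change shown at this aromatic carbon, para to a large group, that lowers the number. The earlier step, an at least 4.0-fold higher number from compound 1 to compound 3 (0.60 log units; beyond the scatter), went the other way at this same place, although on a core with a different group elsewhere, so the series can move in either direction through a single change here. Going by these compounds, the true size of the new step is unknown and may be larger than printed because compound 2 gave a limit rather than a number: the limit of > 500 ug/mL in this assay, at which 2 of the 4 values shown sit.

On these data alone, whether the drop is special to nitro remains open, since an amine or a carboxylic acid at this place could behave differently. Also open, as far as these compounds go, is whether nitro would lower the number on the core of compound 1, and the values shown give no reason for the change.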